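Removing the Isobutyl Group: Cytotoxicity Outlook for Compound 4

This account rests on a few compounds, and the source may have more. Where it says the series, first, only, none or still open, it means among the compounds named here.

Compound 1, `CC(C)N(Cc1cccc(OCCCCCC(=O)O)c1)C(=O)c1ccc(-c2ccncc2)cc1`, in an ADME assay on HEK293 cells (Homo sapiens) for cytotoxicity, read by CellTiter-Glo and resazurin assay, with a stated time of 72 h; a higher number here means that more compound is needed for the effect, a lower number that less compound is needed: > 26000 nM (a limit)
Compound 2, `CC(C)COc1cccc(-c2ccc(C(=O)N(Cc3cccc(OCCCCCC(=O)O)c3)C(C)C)cc2)c1`, in this assay: > 26000 nM (a limit)
Compound 3, `CCOC(=O)CCCCCOc1cccc(CN(C(=O)c2ccc(-c3cccc(OCC(C)C)c3)cc2)C(C)C)c1`, in this assay: > 26000 nM (a limit)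

Compound 3 stands at a limit of this assay rather than at a number. The same holds for compound 1, whose value is a limit. It holds for compound 2 as well, whose value is also a limit. The two measured steps, a step that the two limits leave unreadable from compound 1 to compound 2 and a step that the two limits leave unreadable from compound 2 to compound 3, are therefore of unreadable size, and all that is known is the limit of > 26000 nM in this assay, at which 3 of the 3 values shown sit.

The change now followed is hydrogen in place of isobutyl on an oxygen on an aromatic ring, giving compound 4, `CCOC(=O)CCCCCOc1cccc(CN(C(=O)c2ccc(-c3cccc(O)c3)cc2)C(C)C)c1`. Among the measured compounds shown here, no measured step bears on this change directly; the only guidance is that every measured compound in this assay sits at the limit. Compound 4 is therefore expected to remain at that limit, with a step of a number no higher from compound 3 to compound 4 (the limit leaves the size open) not readable beyond the scatter. The estimate for compound 4 in this assay is 26000 nM, between 13000 nM and 52000 nM, most likely reported again as a limit.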

Compound 4, half-maximal effective concentration: > 26000 nM
Compound 4: a limit, no number (the forecaster's own chance of this, stated with the estimate: 85%); the middle value lies on the limit itself.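

Compound 3 and compound 4 both stand at a limit, so no step between them can be read: the limit of > 26000 nM in this assay, at which 4 of the 4 values shown sit.

The compounds shown leave open how much of any of them is needed for the effect in this assay, and whether any change among them alters it.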